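Enamine nitrogen substituent in a cytotoxicity series

The source may report more compounds than this note shows. Statements on the series, on what has been measured and on what is new or still open speak of the compounds shown alone.

Compound 1 `CCN/C(SC)=C(/C#N)C(=O)Nc1ccc(OCC)cc1` is assessed in a functional assay on CCRF-CEM cells (Homo sapiens) for cytotoxicity, read by resazurin assay, with a stated time of 48 h (a higher number here means a weaker inhibitor, a lower number a stronger inhibitor), where compound 1 gives 9890 nM. Among the measured compounds shown here, compound 2 `CCOc1ccc(-n2nnc3n[nH]c(NC)c3c2=O)cc1`, built on a different core, is the only other measured member of the set; in this assay compound 2 gives 12400 nM. Compound 1 has the lowest of the two numbers, but compound 2 sits within the scatter of it, so no order between the two is claimed. Compound 3 `CCOc1ccc(NC(=O)/C(C#N)=C(\Nc2ccccc2)SC)cc1` differs from compound 1 in one place: phenyl in place of ethyl on an amine nitrogen whose other neighbour is a double-bonded chain carbon; cut one bond further out, the change reads ethylamino to anilino. For the measured compounds named here, no measured pair shows what such a change does, so the size of the step cannot be read from the data. The step of a 1.2-fold lower number from compound 1 to compound 3 (0.09 log units; within the scatter) is expected to stay within the scatter, with no clear direction. In this assay compound 3 is estimated at 8000 nM, with a range from 2500 nM to 25000 nM.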

Compound 3, half-maximal inhibitory concentration: 20300 nM
Beside the measured number, compound 3's estimate is 2.5-fold (0.40 log units) below it; measured number inside the range.
By their numbers in this assay, from the lowest: compounds 1, 2 and 3 (each within the scatter of the next, the first and the last beyond it).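

In this assay, among the compounds shown here, this is the first measured pair at this position, and it gives a 2.1-fold higher number from compound 1 to compound 3 (0.31 log units; beyond the scatter). The amine nitrogen on the double-bonded chain carbon therefore responds to its substituent, though the step is modest, and of this pair the ethylamino form has the lower number, so an aromatic ring set directly on this nitrogen brings no gain here. This reading rests on one pair and one cell line, and nothing at hand accounts for the size or direction of the step.

As far as these compounds go, whether the step follows from the phenyl ring itself or from the loss of the ethyl chain remains open; a cyclohexyl ring, a benzyl group or a longer chain such as butyl on the same nitrogen would separate these readings. Also open, from the compounds shown here alone, is how far the trend runs in either direction, from a methyl group or an unsubstituted amine at one end to a pyridyl ring or a methoxyphenyl group at the other.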